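Clearance notes: oxan-4-yl replaces methoxycyclobutyl at the amide

A few compounds are considered here, and "the series" means these few. Any claim that something is new, unique, unknown or untested is made for them only; others in the source may bear on it.

Three compounds of the series have numbers in an ADME assay on the whole organism (Rattus norvegicus, strain Wistar Han) for metabolic stability; on this read-out lower numbers stand for slow clearance and higher numbers for fast clearance. Compound 1 `CCn1c(-c2ccc(C(F)(F)F)nc2)nc2c(O[C@H]3CCN(C(=O)c4cocn4)C3)ncnc21` gives 13 mL/min/kg. For the measured compounds named here, compound 2 `CCn1c(-c2ccc(C(F)(F)F)nc2)nc2c(O[C@H]3CCN(C(=O)[C@H]4C[C@@H](OC)C4)C3)ncnc21` gives 130 mL/min/kg; the only one-point change measured so far is a 10-fold higher number from compound 1 to compound 2 (1.00 log units; beyond the scatter). Compound 3 `CCn1c(-c2cnc(C)nc2)nc2c(N[C@H]3CCN(C(=O)[C@H]4C[C@@H](OC)C4)C3)ncnc21` carries a different core from compounds 1 and 2. Compound 3 gives 81 mL/min/kg; it stands second highest of the three, its number within the scatter of compound 2 and well above compound 1.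

The next compound, compound 4 `CCn1c(-c2cnc(C)nc2)nc2c(N[C@H]3CCN(C(=O)C4CCOCC4)C3)ncnc21`, differs from compound 3 in one place: oxan-4-yl in place of 3-methoxycyclobutyl on a carbonyl carbon. Going by the values given here, no measured step covers this exchange. The step from compound 1 to compound 2 touches the same carbonyl carbon but swaps a different pair of groups on a different core, so it shows only that this position can move clearance in this assay, not in which direction oxan-4-yl will take it. Given compound 3 at 81 mL/min/kg and no directly comparable step, the expected step is a 1.4-fold lower number from compound 3 to compound 4 (0.13 log units; within the scatter), not beyond the scatter. Compound 4 is therefore estimated at 60 mL/min/kg, with a range from 25 mL/min/kg to 130 mL/min/kg.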

Compound 4, clearance: 220 mL/min/kg
Compound 4: the middle estimate sits 3.7-fold (0.56 log units) below what was measured, outside the stated range (above it).
By their numbers in this assay, from the lowest: compound 1; then compounds 3, 2 and 4 (each within the scatter of the next, the first and the last beyond it).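

In this assay, exchanging 3-methoxycyclobutyl for oxan-4-yl on a carbonyl carbon gives a 2.7-fold higher number from compound 3 to compound 4 (0.43 log units; beyond the scatter) on the core shared by these two compounds. The earlier step at this carbonyl carbon swapped a different pair of groups on another core, whereas here the entering and leaving groups have the same heavy atoms and the same hydrogen-bond counts, yet the number still moves beyond the scatter. They differ in the ring, four-membered and carbon-only against six-membered with one hetero atom, and in the two defined stereocentres of the leaving group, but no measurement available here ties the step to a cause.

Open, from the compounds shown here alone, is whether oxan-4-yl moves the number the same way on the core of compound 2, and whether 1,3-oxazol-4-yl on the core of compound 3 gives a number near that of compound 1 at 13 mL/min/kg in this assay on that core. Also open, going by these compounds, is how a 2-methoxyethyl chain or a primary amine on this carbonyl carbon would read.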